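Arylpiperazine variation in a T-type calcium channel series

This account rests on a few compounds, and the source may have more. Where it says the series, first, only, none or still open, it means among the compounds named here.

Compound 2 `CCCc1nc(-c2ccccc2)c(CNCCCN2CCN(c3cccc(Cl)c3)CC2)o1`: 1750 nM
Compound 1 `CCCc1nc(-c2ccccc2)c(CNCCCN2CCN(c3cccc(F)c3)CC2)o1`: 3030 nM

For the measured compounds named here, in an assay on HEK293 cells for inhibition of Voltage-dependent T-type calcium channel subunit alpha-1G (Homo sapiens), read by patch clamp (on this read-out higher numbers stand for weaker inhibition and lower numbers for stronger inhibition), compound 2 gives 1750 nM, the lowest of the two numbers so far, with compound 1 at 3030 nM. Going by the values given here, the only measured step, a 1.7-fold lower number from compound 1 to compound 2 (0.24 log units; within the scatter), is within the scatter, so the two compounds cannot be told apart on this read-out. Compound 3 `CCCc1nc(-c2ccccc2)c(CNCCCN2CCN(c3cccc(C)c3C)CC2)o1` differs from compound 2 by 2,3-dimethylphenyl in place of 3-chlorophenyl on an amine nitrogen in a ring. Among the compounds with values here, no measured step bears directly on this change: the one step available exchanges fluoro for chloro on the same aromatic ring and shows nothing beyond the scatter, while compound 3 carries two methyl groups and no chloro. Within the data shown here, the sole guide is therefore that the single change seen on this ring left this assay essentially unmoved. Compound 3 is accordingly expected to land near compound 2, with a step of a 1.1-fold higher number from compound 2 to compound 3 (0.06 log units; within the scatter), giving an estimate of 2000 nM within a range from 600 nM to 7000 nM.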

Compound 3, half-maximal inhibitory concentration: 1780 nM
Compound 3: middle estimate off by 1.1-fold (0.05 log units), on the high side, and the stated range covers the measured number.
By their numbers in this assay, from the lowest: compounds 2, 3 and 1 (each within the scatter of the next).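

In this assay, 2,3-dimethylphenyl in place of 3-chlorophenyl on the ring amine nitrogen gives a 1.0-fold higher number from compound 2 to compound 3 (0.01 log units; within the scatter), and in place of 3-fluorophenyl it gives a 1.7-fold lower number from compound 1 to compound 3 (0.23 log units; within the scatter), both within the scatter. The earlier pair differed only in its halogen, whereas this result shows that a phenyl group with two methyl groups and no halogen at this position also cannot be told apart from the halogen-bearing compounds on this read-out. Nothing measured here explains why these three groups read alike.

From the compounds shown here alone, it remains open whether a different group on this nitrogen, such as a pyridine ring, a benzyl group or a phenyl bearing a carboxylic acid, would move the number beyond the scatter. It is also open whether the close values of these compounds would hold with an amide in place of the chain amine.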